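The source may report more compounds than this note shows. Statements on the series, on what has been measured and on what is new or still open speak of the compounds shown alone.

Compound 1 `CC(C)n1c(/C=C2/C(=O)Nc3ccc(F)cc32)nc2ccccc21`: 29000 nM
Compound 2 `Cn1c(/C=C2/C(=O)Nc3ccc(Br)cc32)nc2ccccc21`: > 50000 nM (a limit)

Both compounds were tested in a functional assay on MCF7 cells (Homo sapiens) for cytotoxicity, read by MTT assay, with a stated time of 48 h; a lower number here means a stronger inhibitor, a higher number a weaker inhibitor. Compound 2 has no exact number, only the limit > 50000 nM. On these data alone, its true position therefore remains open, and the limit of > 50000 nM in this assay, at which 1 of the 2 values shown sits, is all that can be said of it.

Compound 3 `Cn1c(/C=C2/C(=O)Nc3ccc(F)cc32)nc2ccccc21` has not yet been measured. It differs from compound 2 by fluoro in place of bromo on an aromatic carbon. Within the data shown here, no step between measured compounds is available to size this change. The expectation rests instead on compound 1, which gives 29000 nM and thus also shows only weak activity. In this assay, the expected step of an at least 1.2-fold lower number from compound 2 to compound 3 (0.09 log units; that floor lies within the scatter) is small, with no change beyond the scatter and no firm direction. For compound 3 the estimated value is 40000 nM, with an expected range of 17000 nM to 90000 nM.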

Compound 3, half-maximal inhibitory concentration: 31600 nM
Estimate against measurement, compound 3: 1.3-fold (0.10 log units) above; the range from low to high includes it.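

In this assay, the exchange of bromo for fluoro on the aromatic carbon comes to an at least 1.5-fold lower number from compound 2 to compound 3 (0.19 log units; that floor lies within the scatter). Only a floor is known for this step, since compound 2 carries a limit and not a number: the limit of > 50000 nM in this assay, at which 1 of the 3 values shown sits.

The second new step, methyl in place of isopropyl on the aromatic nitrogen with fluoro on the ring, is a 1.1-fold higher number from compound 1 to compound 3 (0.04 log units; within the scatter), so the two nitrogen groups cannot be told apart here.

The compounds shown leave open whether the true gap between bromo and fluoro lies beyond the scatter, and how isopropyl on the nitrogen reads with bromo on the ring. They also leave open whether an amine or a carboxylic acid on this aromatic carbon, or a longer chain on the nitrogen, would give a clearly lower number.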